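Adding a methoxy group to the para-unsubstituted benzylidene

The compounds below may be only part of what the source reports. "The series", "measured", "known", "first", "only" and "open" are said of these compounds alone.

Of the compounds shown here, three with a shared core have been measured in an assay on HL-60 cells for inhibition of glutathione S-transferase P (Homo sapiens), read by spectrophotometry, tested at 20 uM; a lower number here means less inhibition, a higher number more inhibition at the concentration tested (going by the name of the read-out). Compound 1 `COc1ccccc1/C=C1\CN(CC(=O)O)c2c(C)cccc2C1=O` gives 4.72%, compound 2 `CCOc1ccc(/C=C2\CN(CC(=O)O)c3c(C)cccc3C2=O)cc1` gives 42.4%, and compound 3 `Cc1cccc2c1N(CC(=O)O)C/C(=C\c1ccccc1)C2=O` gives 27.9%. Among these three numbers compound 3 stands second highest: compound 2 lies above it, a number 14.5 percentage points lower from compound 2 to compound 3 (beyond the scatter), and compound 1 lies below it, a number 23.2 percentage points higher from compound 1 to compound 3 (beyond the scatter).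

Compound 4 `COc1ccc(/C=C2\CN(CC(=O)O)c3c(C)cccc3C2=O)cc1` is compound 3 with one change, (methoxy in place of hydrogen on an aromatic carbon), the new group sitting on an aromatic carbon para to a large group. Within the data shown here, two measured steps bear on this. From compound 2 to compound 3 an ethoxy at that same place was removed, and the reading fell by a modest, real amount. From compound 1 to compound 3 a methoxy was removed from a different aromatic carbon, and the reading rose. Since the new methoxy enters at the place the ethoxy occupied, a modest rise is expected in this assay, a number 10.1 percentage points higher from compound 3 to compound 4 (beyond the scatter), landing near compound 2 rather than compound 1. Compound 4 is therefore estimated at 38%, within a range of 25% to 52%.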

Compound 4, a percentage reported as inhibition, at one concentration (the size of the read-out at that concentration, not a potency): 31.5%
The estimate for compound 4 lay 6.5 percentage points above the measured number; the range from low to high includes it.
By their numbers in this assay, from the lowest: compound 1; then compounds 3 and 4 (each within the scatter of the next); then compound 2.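

In this assay, the step of a number 3.6 percentage points higher from compound 3 to compound 4 (within the scatter) shows that a methoxy on this aromatic carbon, para to a large group, cannot be told apart from hydrogen. Ethoxy at the same place can, since the step of a number 10.9 percentage points lower from compound 2 to compound 4 (beyond the scatter) separates it from methoxy, so among compounds 2, 3 and 4 only the ethoxy stands out, and the oxygen alone does not account for the higher reading. Where the methoxy sits also counts, with the change from 2-methoxyphenyl to 4-methoxyphenyl giving a number 26.8 percentage points higher from compound 1 to compound 4 (beyond the scatter) on the same core.

No measurement shown here explains any of these differences. From the compounds shown here alone, whether a longer chain such as propoxy would raise the reading further at this place, or how an amine or a hydroxyl would behave there, remains open.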